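The compounds below may be only part of what the source reports. "The series", "measured", "known", "first", "only" and "open" are said of these compounds alone.

Of the compounds shown here, three built on one shared core have been tested in an ADME assay on the whole organism with Oryza sativa as the target, tested at 0.1 uM; a lower number here means a stronger effect, a higher number a weaker effect of the compound at the concentration tested. Compound 1 `CCCc1ccc(NC(=O)N[C@@H](C)c2ccccc2)cc1` gives 97% there. For the measured compounds named here, compound 2 `CCOC(=O)c1ccc(NC(=O)N[C@@H](C)c2ccccc2)cc1` gives 99% in this assay, and the single one-change step among the measured compounds, a number 2 percentage points higher from compound 1 to compound 2 (within the scatter), is small. Compound 3 `CC(=O)c1ccc(NC(=O)N[C@H](C)c2ccccc2)cc1` gives 96% in this assay; its number lies within the usual scatter of both companions, nearer to that of compound 1 and further from that of compound 2, so no real separation between the three can be claimed.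

Going by the values given here, compound 4 `CC(=O)c1ccc(NC(=O)N[C@@H](C)c2ccccc2)cc1` has not yet been measured. the two compounds have the same atoms and bonds and differ only in configuration as drawn: 1 of 1 stereo elements differ; a stereocentre at a saturated chain carbon is drawn R in compound 3 and S in compound 4 No measured step consists of a change in configuration alone, so none bears directly on this one. Among the compounds with values here, what the numbers do show is that compound 1 and compound 2, which carry the same configuration as drawn for compound 4, sit within the scatter of compound 3, and that the only measured step, a number 2 percentage points higher from compound 1 to compound 2 (within the scatter), stayed within the scatter as well. The step expected is therefore a number 1 percentage points higher from compound 3 to compound 4 (within the scatter), nothing beyond the scatter. Compound 4 is estimated at 97% in this assay, with a range from 91% to 100%.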

Compound 4, a percentage reported as activity, at one concentration (the size of the read-out at that concentration, not a potency): 99%
For compound 4 the middle estimate is 2 percentage points below the measured one; low and high end bracket the measured number.
By their numbers in this assay, from the lowest: compounds 3, 1, 2 and 4 (each within the scatter of the next).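

In this assay, for the compounds shown here, the change of configuration alone at the stereocentre on the saturated chain carbon now has a direct reading, a number 3 percentage points higher from compound 3 to compound 4 (within the scatter), so drawing this centre R or S gives no separation in this pair at this concentration, and this step can be read as a test of configuration and nothing else because of one fact: the fact that compounds 3 and 4 differ only in the configuration as drawn. With the S configuration held fixed, putting acetyl in place of propyl on the aromatic carbon gives a number 2 percentage points higher from compound 1 to compound 4 (within the scatter), and methyl in place of ethoxy on the carbonyl carbon gives no change at the digits printed from compound 2 to compound 4 (within the scatter). Propyl, ethoxycarbonyl and acetyl at this place on the shared core therefore cannot be told apart in this assay, and the earlier compounds alone could compare only the first two.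

On these data alone, whether an amine or a carboxylic acid in place of the acetyl on the aromatic carbon would give a step beyond the scatter stays open. Going by these compounds alone, also open is whether configuration would stay just as silent with propyl or ethoxycarbonyl in that place, as the only pair that tests it carries acetyl.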